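Mirror image of compound 3 in the kinase binding assay

The compounds below may be only part of what the source reports. "The series", "measured", "known", "first", "only" and "open" are said of these compounds alone.

Measured so far, in a binding assay on isolated protein for inhibition of protein kinase C delta type (Homo sapiens), read by TR-FRET, with a stated time of 2 h; a lower number here means a stronger inhibitor, a higher number a weaker inhibitor:
- compound 1 `N#Cc1cnc(NCc2cnccc2C(F)(F)F)cc1NC[C@H]1C[C@H](O)C1`: compound 1 gives > 10000 nM, which is a limit of the assay and not a number (the limit of > 10000 nM in this assay, at which 1 of the 3 values shown sits).
- compound 2 `N#Cc1cnc(NCc2cnccc2C(F)(F)F)cc1NCC1CCOCC1`: compound 2 gives 5000 nM.
- compound 3 `CC1(C)[C@@H](C(N)=O)C[C@H]1Nc1cc(NCc2cnccc2C(F)(F)F)ncc1C#N`: compound 3 gives 160 nM.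

Compound 3 stands lowest of the two numbers shown; the nearest is compound 2, with a 31-fold lower number from compound 2 to compound 3 (1.49 log units; beyond the scatter), and from the limit of compound 1 the step is an at least 62-fold lower number from compound 1 to compound 3 (1.79 log units; beyond the scatter). The step of an at least 2.0-fold lower number from compound 1 to compound 2 (0.30 log units; that floor lies within the scatter) lies within the scatter.

Compound 4 `CC1(C)[C@@H](Nc2cc(NCc3cnccc3C(F)(F)F)ncc2C#N)C[C@H]1C(N)=O` differs from compound 3 by the two compounds have the same atoms and bonds and differ only in configuration as drawn: 2 of 2 stereo elements differ (all stereocentres are inverted: mirror images); a stereocentre at a saturated ring carbon is drawn R in compound 3 and S in compound 4; a stereocentre at a saturated ring carbon is drawn S in compound 3 and R in compound 4. Each measured step exchanged the substituent on the nitrogen of the shared core for a different one; none of them changed only configuration, so none bears directly on this step. Mirror images of one structure may differ widely in this assay or not at all, and the measured steps give no direction. The expected step of a 7.5-fold higher number from compound 3 to compound 4 (0.88 log units; beyond the scatter) is therefore given with a wide range, leaning toward a weaker inhibitor. Compound 4 is estimated at 1200 nM, with a range from 150 nM to 10000 nM in this assay.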

Compound 4, half-maximal inhibitory concentration: 4500 nM
For compound 4 the middle estimate is 3.8-fold (0.57 log units) below the measured one; the range from low to high includes it.
By their numbers in this assay, from the lowest: compound 3; then compounds 4 and 2 (each within the scatter of the next). At a limit, above all of these: compound 1.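

In this assay, configuration alone separates the mirror pair, a 28-fold higher number from compound 3 to compound 4 (1.45 log units; beyond the scatter), so the standing of compound 3 depends on how the 3-carbamoyl-2,2-dimethylcyclobutyl group is arranged and not only on its presence, because: the fact that compounds 3 and 4 differ only in the configuration as drawn. In the other configuration the same group gives no separation from (oxan-4-yl)methyl, a 1.1-fold lower number from compound 2 to compound 4 (0.05 log units; within the scatter). Compound 1 sits at a limit of the assay and not a number, so its step reads only as a floor: an at least 2.2-fold lower number from compound 1 to compound 4 (0.34 log units; beyond the scatter).

The compounds shown leave open how the forms with only one of the two stereocentres inverted would compare with this pair. They also leave open whether a carboxylic acid or a methyl ester in place of the carbamoyl group would keep the separation between mirror images.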